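Notes on the step from compound 3 to compound 4

This account rests on a few compounds, and the source may have more. Where it says the series, first, only, none or still open, it means among the compounds named here.

Measured compounds, with a functional assay on HL-60 cells (Homo sapiens) for cytotoxicity, read by luminescence and CellTiter-Glo, with a stated time of 3 days; a lower number here means a stronger inhibitor, a higher number a weaker inhibitor:
- compound 1 `CN(C(=O)c1cc(F)ccc1O)c1ccc(C#N)cc1`: > 10000 nM
- compound 2 `O=C(Nc1ccc(Cl)c(Br)c1)c1cc(Cl)ccc1O`: 780 nM
- compound 3 `N#Cc1ccc(NC(=O)c2cc(Cc3ccccc3)ccc2O)cc1`: 1740 nM

Compound 1 gives only a limit in this assay, (the limit of > 10000 nM in this assay, at which 1 of the 3 values shown sits), so its value is not a number. Within the data shown here, of the two numbers that remain, compound 3 holds the higher one and compound 2 the lower one, and the gap between compound 2 and compound 3 lies beyond the scatter; compound 2 is therefore the stronger inhibitor of the two in this assay, and no further compound is measured beside them.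

Compound 4 `N#Cc1ccc(NC(=O)c2cc(Br)ccc2O)cc1` is still to be measured in this assay. It differs from compound 3 in one place: bromo in place of benzyl on an aromatic carbon.

Among the measured compounds shown here, no measured pair shows exactly this change, so the size of the step is open. Compound 2, which also carries a halogen on the same ring, sits lower than compound 3 in this assay, and a small gain in the same direction is expected for compound 4, within or near the scatter, as a 1.7-fold lower number from compound 3 to compound 4 (0.24 log units; within the scatter). Compound 4 is therefore estimated at 1000 nM, within a range from 350 nM to 3000 nM.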

Compound 4, half-maximal inhibitory concentration: 620 nM
Compound 4: the middle estimate sits 1.6-fold (0.21 log units) above what was measured; measured number inside the range.
By their numbers in this assay, from the lowest: compounds 4 and 2 (each within the scatter of the next); then compound 3. At a limit, above all of these: compound 1.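

On the aromatic carbon para to a hydroxy group, bromo in place of benzyl gives a 2.8-fold lower number from compound 3 to compound 4 (0.45 log units; beyond the scatter) in this assay. Among these compounds, this is the first step that can be read at this position: a single bromine atom replaces a group of 7 heavy atoms with a six-membered aromatic ring, and the number falls modestly rather than rises, so the benzyl ring is not required to hold the activity seen in compound 3. Nothing measured here gives a reason for this step.

On these data alone, only benzyl and bromo can be compared directly at this position, and how a methoxy group, an amine or a carboxylic acid would read there remains open. Also open, as far as these compounds go, is whether the same change gives a step of like size when another group stands in place of the nitrile.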